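From a Butyl Chain to a Cyclobutyl Ring

The source may report more compounds than this note shows. Statements on the series, on what has been measured and on what is new or still open speak of the compounds shown alone.

Compound 1 `CCCCCN(C1=NCCN1)c1c(Br)cccc1Br` was examined in a physicochemical assay for acid dissociation, and gives 11. Among the compounds with values here, its only measured neighbour is compound 2 `C#CCN(C1=NCCN1)c1c(Br)cccc1Br`, which carries ethynyl in place of butyl on a saturated chain carbon bound to a nitrogen on an aromatic ring and in this assay gives 10.1. This makes compound 1 the higher of the two numbers, with a number 0.90 log units lower from compound 1 to compound 2 (beyond the scatter).

Compound 3 `Brc1cccc(Br)c1N(CC1CCC1)C1=NCCN1` is not yet measured. It differs from compound 1 as follows: cyclobutyl in place of butyl on a saturated chain carbon bound to a nitrogen on an aromatic ring. Within the data shown here, the one step recorded so far, from compound 1 to compound 2, replaced butyl with ethynyl and lowered the acid dissociation constant by a modest amount beyond the scatter. That step bears on compound 3 only loosely: cyclobutyl, like butyl, is a group of four carbon atoms with no ring atoms other than carbon and no donors or acceptors, whereas ethynyl is a different kind of group altogether. With no closer comparison available, compound 3 is expected to sit close to compound 1, with a number 0.10 log units lower from compound 1 to compound 3 (within the scatter) lying within the usual scatter. Compound 3 is therefore estimated at 10.9, in a range from 10.4 to 11.3.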

Compound 3, acid dissociation constant: 10.9
Beside the measured number, compound 3's estimate shows no gap at the digits printed, and the stated range covers the measured number.
By their numbers in this assay, from the lowest: compound 2; then compounds 3 and 1 (each within the scatter of the next).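

In this assay, cyclobutyl in place of butyl at this position, on a saturated chain carbon bound to a nitrogen on an aromatic ring, gives a number 0.10 log units lower from compound 1 to compound 3 (within the scatter) and so the read-out does not separate the four-membered ring of carbon only from the open chain. Cyclobutyl in place of ethynyl gives a number 0.80 log units higher from compound 2 to compound 3 (beyond the scatter) and this modest step is close in size to the earlier one, a number 0.90 log units lower from compound 1 to compound 2 (beyond the scatter) and together they leave ethynyl as the only one of the three groups that stands apart from the other two, on the lower side. No measurement shown here offers an explanation for these numbers.

As far as these compounds go, the groups compared at this position all consist of carbon alone, so it remains open where the number would fall with an amine or a carboxylic acid on the chain. From the compounds shown here alone, it also remains open whether a longer chain or a cyclohexyl ring would stay as close to compound 1 as the cyclobutyl group of compound 3 does.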